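The source may report more compounds than this note shows. Statements on the series, on what has been measured and on what is new or still open speak of the compounds shown alone.

Measured compounds in a functional assay on CCRF-CEM cells (Homo sapiens) for inhibition, read by MTT assay, with a stated time of 72 h; a lower number here means a stronger inhibitor, a higher number a weaker inhibitor:
compound 1 `COc1cc(NC(C)CCCNC(=O)Nc2ccc(F)cc2)c2ncccc2c1` gives 26000 nM
compound 2 `COc1cc(NC(C)CCCNC(=O)Nc2ccc(O)cc2)c2ncccc2c1` gives 23000 nM
compound 3 `COc1cc(NC(C)CCCNC(=O)NNC(=O)Nc2ccc(O)cc2)c2ncccc2c1` gives 111000 nM

Among these three, compound 3 has the highest number: a 4.3-fold higher number from compound 1 to compound 3 (0.63 log units; beyond the scatter) and a 4.8-fold higher number from compound 2 to compound 3 (0.68 log units; beyond the scatter) both lie beyond the scatter. Compound 4 `COc1cc(NC(C)CCCNC(=O)NNC(=O)Nc2ccc(C(F)(F)F)cc2)c2ncccc2c1` differs from compound 3 in a single place: trifluoromethyl in place of hydroxy on an aromatic carbon. For the measured compounds named here, the only measured step at the same position of that ring is a 1.1-fold lower number from compound 1 to compound 2 (0.05 log units; within the scatter), which stayed within the scatter. Going by the values given here, no measured compound carries a trifluoromethyl group, so no step bears on this exchange directly. For compound 4, the expected step is therefore a 1.2-fold lower number from compound 3 to compound 4 (0.09 log units; within the scatter), within the scatter. The estimate for compound 4 in this assay is 90000 nM, with a range from 30000 nM to 270000 nM.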

Compound 4, half-maximal inhibitory concentration: 18000 nM
Estimate against measurement, compound 4: 5.0-fold (0.70 log units) above, and the stated range ends above it.
By their numbers in this assay, from the lowest: compounds 4, 2 and 1 (each within the scatter of the next); then compound 3.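

In this assay, a change at this position of the aromatic ring can shift the number beyond the scatter: a 6.2-fold lower number from compound 3 to compound 4 (0.79 log units; beyond the scatter) for trifluoromethyl in place of hydroxy. For the compounds shown here, the only earlier step at this position, hydroxy in place of fluoro, gave a 1.1-fold lower number from compound 1 to compound 2 (0.05 log units; within the scatter) and stayed within the scatter, although it was read on the chain of compound 1 and compound 2. Nothing available explains this difference between the two steps.

As far as these compounds go, it remains open whether trifluoromethyl would have a similar effect on the chain of compound 1 and compound 2. From the compounds shown here alone, how an amine or a carboxylic acid at this position would read also remains open.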